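A Chalcone Series Where Nothing Has Yet Shown Activity

The compounds below may be only part of what the source reports. "The series", "measured", "known", "first", "only" and "open" are said of these compounds alone.

Two chalcones have been tested in a functional assay on HepG2 cells (Homo sapiens) for antiproliferative activity, read by MTT assay, with a stated time of 24 h (a lower number here means a stronger inhibitor, a higher number a weaker inhibitor), so far. Compound 1, with the structure `COc1ccc(/C=C/C(=O)c2ccc(OC)c3c2OC(C)(C)C=C3)cn1`, carries a 6-methoxypyridin-3-yl group on the double-bonded chain. In this assay compound 1 gives > 10000 nM, which is a limit of the assay rather than a number. Compound 2, the structure `COc1ccc(C(=O)/C=C/c2ccc(OC)c(OC)c2OC)c2c1C=CC(C)(C)O2`, also reaches only a limit, giving > 10000 nM in this assay. Among the compounds with values here, compound 1 therefore stands at the same limit as the one other value shown, and the only evidence available is the limit of > 10000 nM in this assay, at which 2 of the 2 values shown sit. Compound 3, the structure `COc1ccccc1/C=C/C(=O)c1ccc(OC)c2c1OC(C)(C)C=C2`, remains to be measured; it differs from compound 1 by 2-methoxyphenyl in place of 6-methoxypyridin-3-yl on a double-bonded chain carbon bound to a double-bonded chain carbon. With both known compounds sitting at the limit, no step beyond the usual scatter is expected, and the expected step that the limit leaves unreadable from compound 1 to compound 3 is essentially flat. Compound 3 is therefore estimated at 20000 nM, with a range from 5000 nM to 80000 nM.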

Compound 3, half-maximal inhibitory concentration: > 10000 nM
Compound 3: a limit, no number; the forecaster's own chance of this, stated with the estimate: 75%; the middle value lies beyond the limit too.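

In this assay compound 3 gives > 10000 nM, which is a limit and not a number. Within the data shown here, compound 1 also stands at a limit, so no step between compound 1 and compound 3 can be read. Whether any compound of this kind gives a measurable value stays open, and the evidence so far is this: the limit of > 10000 nM in this assay, at which 3 of the 3 values shown sit.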